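Trading a pentylphenyl for trimethylsilyl on the triazole

This account rests on a few compounds, and the source may have more. Where it says the series, first, only, none or still open, it means among the compounds named here.

Compound 1 `O=C1O[C@H]([C@@H](O)Cn2cc(-c3cc(C(F)(F)F)cc(C(F)(F)F)c3)nn2)C(OCc2ccccc2)=C1OCc1ccccc1`: 33800 nM in this assay.
Compound 2 `CCCCCc1ccc(-c2cn(C[C@H](O)[C@H]3OC(=O)C(OCc4ccccc4)=C3OCc3ccccc3)nn2)cc1`: 7460 nM in this assay.
Compound 3 `COc1ccc(-c2cn(C/C=C3\OC(=O)C(OCc4ccccc4)=C3OCc3ccccc3)nn2)cc1`: > 100000 nM in this assay, a limit rather than a number.

Of the compounds shown here, three sharing the same core have been tested in a functional assay on HepG2 cells (Homo sapiens) for antiproliferative activity, read by MTT assay, with a stated time of 72 h; a higher number here means a weaker inhibitor, a lower number a stronger inhibitor. Of the two that give a number, compound 2 holds the lower one, with 7460 nM, while compound 1 stands at a higher value of 33800 nM, a gap that lies beyond the usual scatter. Compound 3 gives only a limit in this assay, > 100000 nM, so it can be placed only as no stronger than that.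

Compound 4 `C[Si](C)(C)c1cn(C[C@H](O)[C@H]2OC(=O)C(OCc3ccccc3)=C2OCc2ccccc2)nn1` has not yet been measured. It differs from compound 2 in one place: a group of 4 heavy atoms (3 carbon, 1 silicon; no ring) in place of a group of 11 heavy atoms (11 carbon; one six-membered aromatic ring of carbon only), on an aromatic carbon. Within the data shown here, no pair of measured compounds differs in a single place, so no measured step directly guides this change. The three compounds do show that the group on the triazole ring matters, with compound 2 the only one reaching the lower range. Compound 4 is expected to fall back toward the weaker compounds, a step of a 3.4-fold higher number from compound 2 to compound 4 (0.53 log units; beyond the scatter) in this assay. The estimate for compound 4 in this assay is 25000 nM, with a likely range from 6000 nM to 90000 nM.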

Compound 4, half-maximal inhibitory concentration: 24100 nM
Compound 4: the middle estimate sits 1.0-fold (0.02 log units) above what was measured; the measured number falls inside the stated range.
By their numbers in this assay, from the lowest: compound 2; then compounds 4 and 1 (each within the scatter of the next). At a limit, above all of these: compound 3.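

Among these compounds, putting trimethylsilyl in place of 4-pentylphenyl on this aromatic carbon of the five-membered aromatic ring with 3 nitrogen gives a 3.2-fold higher number from compound 2 to compound 4 (0.51 log units; beyond the scatter) in this assay, the first reading of a change made at this position alone. Among the compounds shown here, the earlier compounds could show only that numbers differ across compounds that differ in more than one place, whereas this step ties a difference beyond the scatter to this one group. It also shows that a group with no ring at this position still gives a number, not a limit, yet no measurement shown here explains the step.

The exchange removes the aromatic ring and the pentyl chain together, so the compounds shown cannot say which of the two carries the difference; a plain phenyl or a bare pentyl chain on the same carbon would separate them. As far as these compounds go, it also remains open how this position would respond to a group carrying an amine or a carboxylic acid, or to a longer chain on the phenyl ring.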